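The source may report more compounds than this note shows. Statements on the series, on what has been measured and on what is new or still open speak of the compounds shown alone.

Measured in a functional assay on MCF7 cells (Homo sapiens) for cytotoxicity, read by MTT assay, with a stated time of 72 h; a lower number here means a stronger inhibitor, a higher number a weaker inhibitor:
- compound 1 `COc1cccc(/C=C2\CCC/C(=C\c3cccc(Cl)c3)C2=O)c1OC`: 12000 nM
- compound 2 `COc1cccc(/C=C2\CCC/C(=C\c3ccc(Cl)cc3Cl)C2=O)c1OC`: > 20000 nM, a limit of the assay
- compound 3 `COc1cccc(/C=C2\CCC/C(=C\c3ccc(Cl)c(Cl)c3)C2=O)c1OC`: 9000 nM

Only compound 1 and compound 3 carry actual numbers, and these two are not separated: a 1.3-fold lower number from compound 1 to compound 3 (0.12 log units; within the scatter). The third entry is different in kind, as the series contains (the limit of > 20000 nM in this assay, at which 1 of the 3 values shown sits). Measured against that limit, the step is an at least 2.2-fold lower number from compound 2 to compound 3 (0.34 log units; beyond the scatter).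

Next comes compound 4 `COc1cccc(/C=C2\CCC/C(=C\c3ccc(O)c(O)c3)C2=O)c1OC`, which has 3,4-dihydroxyphenyl in place of 3,4-dichlorophenyl on a double-bonded chain carbon bound to a double-bonded ring carbon.

Going by the values given here, no measured step replaces chloro with hydroxy, so the evidence is indirect. Adding a chloro to the aromatic ring gave a 1.3-fold lower number from compound 1 to compound 3 (0.12 log units; within the scatter), a change that stays within the scatter. The other step from the number of compound 1 is an at least 1.6-fold higher number from compound 1 to compound 2 (0.22 log units; that floor lies within the scatter), which is only a floor. Among the compounds with values here, the one step beyond the scatter exchanges 2,4-dichlorophenyl for 3,4-dichlorophenyl, a change not made here. These steps give no ground for a direction, so no shift beyond the scatter is expected in this assay. The expected step is a 1.3-fold lower number from compound 3 to compound 4 (0.11 log units; within the scatter). For compound 4 the estimated value is 7000 nM, with an expected range from 2000 nM to 20000 nM.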

Compound 4, half-maximal inhibitory concentration: 4700 nM
Compound 4: the middle estimate sits 1.5-fold (0.17 log units) above what was measured; low and high end bracket the measured number.
By their numbers in this assay, from the lowest: compounds 4, 3 and 1 (each within the scatter of the next, the first and the last beyond it). At a limit, above all of these: compound 2.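

In this assay, compound 4 shows that this place on a double-bonded chain carbon bound to a double-bonded ring carbon tolerates a group with hydrogen-bond donors and acceptors, since 3,4-dichlorophenyl, which has neither, gives way to 3,4-dihydroxyphenyl without a change beyond the scatter (a 1.9-fold lower number from compound 3 to compound 4 (0.28 log units; within the scatter)). Compound 4 also separates from the other two chlorinated compounds, a separation that compound 3 reached from compound 2 but not from compound 1 (a 2.6-fold lower number from compound 1 to compound 4 (0.41 log units; beyond the scatter); an at least 4.2-fold lower number from compound 2 to compound 4 (0.62 log units; beyond the scatter)). The step involving compound 2 is only a floor, and the value of compound 2 is a limit of the assay, not a number: (the limit of > 20000 nM in this assay, at which 1 of the 4 values shown sits).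

The compounds shown leave open whether both hydroxy groups of 3,4-dihydroxyphenyl are needed, as no compound here carries a single hydroxy or a methoxy at this place on the second aryl group. Also open, from the compounds shown here alone, is how an amine or a carboxylic acid on that ring would read in this assay, and whether the shared core would keep these numbers with a longer chain in place of either aryl group.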